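The compounds below may be only part of what the source reports. "The series", "measured", "known", "first", "only" and "open" are said of these compounds alone.

Of the compounds shown here, three that share one core have been tested in an assay on CHO cells for displacement of a labelled ligand from adenosine receptor A1 (Homo sapiens), read by scintillation counting, tested at 10 uM; on this read-out lower numbers stand for less inhibition and higher numbers for more inhibition at the one concentration tested (going by the name of the read-out). Compound 1 `CC(C)(C)c1csc(N)c1C(=O)c1ccc(Cl)cc1` gives 1%. Compound 2 `CC(C)(C)Cc1c(-c2cccnc2)sc(N)c1C(=O)c1ccc(Cl)cc1` gives 1%. Compound 3 `CC(C)(C)Cc1c(-c2ccc(F)cc2F)sc(N)c1C(=O)c1ccc(Cl)cc1` gives 1%, so at the digits shown compound 3 stands level with compound 1 and compound 2, and the inhibition in this assay is level across the three. Among the measured compounds shown here, the only step between measured compounds that differ in a single place is no change at the digits printed from compound 2 to compound 3 (within the scatter), where a 2,4-difluorophenyl group takes the place of a pyridin-3-yl group on an aromatic carbon, and the read-out did not move beyond the scatter.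

Compound 4 `Cc1ccccc1-c1sc(N)c(C(=O)c2ccc(Cl)cc2)c1CC(C)(C)C` has not yet been measured. Compared with compound 3 it differs in one place: 2-methylphenyl in place of 2,4-difluorophenyl on an aromatic carbon. The earlier step is the one that bears on this change, since it too exchanged one six-membered aromatic ring for another on an aromatic carbon of the core. Because that earlier swap gave no change at the digits printed from compound 2 to compound 3 (within the scatter), and because compound 1, compound 2 and compound 3 all sit at the same reading, no movement beyond the scatter is expected. Compound 4 is thus expected to show a step of no change at the digits printed from compound 3 to compound 4 (within the scatter). Compound 4 is therefore estimated to give about 1% in this assay, most likely between -6% and 10%.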

Compound 4, a percentage reported as inhibition, at one concentration (the size of the read-out at that concentration, not a potency): 1%
For compound 4 middle estimate and measured number coincide at the digits printed, within the range that was stated.
By their numbers in this assay, from the lowest: compounds 1, 2, 3 and 4 (each within the scatter of the next).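

On the aromatic carbon next to the ring sulfur, 2-methylphenyl in place of 2,4-difluorophenyl gives no change at the digits printed from compound 3 to compound 4 (within the scatter) in this assay, and 2-methylphenyl in place of pyridin-3-yl gives no change at the digits printed from compound 2 to compound 4 (within the scatter). Among the compounds shown here, the earlier compounds had only compared a ring bearing two fluorines with a ring containing nitrogen, so this result adds a third kind of ring, one of carbon only that carries a methyl group, and the reading still does not shift beyond the scatter. No measurement here explains this flat result.

All three rings at this position give the same very small reading, so the compounds shown cannot rank these groups or reveal any that raises inhibition at the one concentration tested. From the compounds shown here alone, what a carboxylic acid, an aminomethyl group or a longer chain such as n-hexyl would do on this carbon stays open, as does the effect of replacing the neopentyl group or the (4-chlorophenyl)carbonyl group on the shared core.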